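A few compounds are considered here, and "the series" means these few. Any claim that something is new, unique, unknown or untested is made for them only; others in the source may bear on it.

Measured so far:
compound 1 `COc1ccccc1NC(=O)N1CCC(c2noc(-c3ccc4ccccc4n3)n2)CC1` gives 2400 nM
compound 2 `CC(=O)N1CCC(NC(=O)N2CCC(c3nc(-c4ccc5ccccc5n4)no3)CC2)CC1` gives 500 nM

Both numbers come from a functional assay on Shh Light II cells (Mus musculus) for inhibition, read by a luciferase reporter; on this read-out higher numbers stand for weaker inhibition and lower numbers for stronger inhibition. Compound 2 stands lowest of the two; compound 1 sits higher, beyond the scatter. Compound 3 `O=C(NC1CCCCC1)N1CCC(c2nc(-c3ccc4ccccc4n3)no2)CC1` is not yet measured. It differs from compound 2 in one place: cyclohexyl in place of 1-acetylpiperidin-4-yl on an amide-type nitrogen. Among the measured compounds shown here, no measured pair shows this change, so the size of the step is open. The step is expected to be small, toward weaker inhibition: a 1.4-fold higher number from compound 2 to compound 3 (0.15 log units; within the scatter). In this assay compound 3 is estimated at 700 nM, within a range of 250 nM to 2000 nM.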

Compound 3, half-maximal inhibitory concentration: 57 nM
For compound 3 the middle estimate is 12-fold (1.09 log units) above the measured one, outside the stated range (below it).
By their numbers in this assay, from the lowest: compound 3; then compound 2; then compound 1.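

In this assay, among the compounds shown here, cyclohexyl in place of 1-acetylpiperidin-4-yl on the amide-type nitrogen gives an 8.8-fold lower number from compound 2 to compound 3 (0.94 log units; beyond the scatter) as the first single-place step. This position is therefore sensitive to the group it carries, and the carbon-only ring is the better of the two shown. No supporting data bear on the origin of this gain. The compounds shown leave open whether the acetyl group or the ring nitrogen matters, which a free piperidin-4-yl amine could separate. They also leave open whether cyclopentyl or an open hexyl chain would hold this level.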